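Series notes: aryl in place of benzyl on the core

A few compounds are considered here, and "the series" means these few. Any claim that something is new, unique, unknown or untested is made for them only; others in the source may bear on it.

Measured so far in a functional assay on CCRF-CEM cells (Homo sapiens) for inhibition, read by cell counting, with a stated time of 3 days; on this read-out higher numbers stand for weaker inhibition and lower numbers for stronger inhibition:
Compound 1 `C=C(Br)C(=O)Nc1cccc(-c2cn3nc(Cc4cccc(OC)c4)sc3n2)c1`: 3100 nM
Compound 2 `Nc1cccc(-c2cn3nc(Cc4ccc(Cl)cc4)sc3n2)c1`: 42000 nM
Compound 3 `COc1cccc(Cc2nn3cc(-c4cccc(N)c4)nc3s2)c1`: 40000 nM

Compound 1 gives the lowest of the three numbers in this assay. Among the compounds with values here, its nearest neighbour is compound 3, where the step is a 13-fold higher number from compound 1 to compound 3 (1.11 log units; beyond the scatter), the only change being hydrogen in place of (1-bromoethenyl)carbonyl on a nitrogen on an aromatic ring. Compound 2 stands a little further off from compound 1, and the step of a 1.1-fold lower number from compound 2 to compound 3 (0.02 log units; within the scatter) shows that 3-methoxyphenyl in place of 4-chlorophenyl on the saturated chain carbon bound to an aromatic carbon made no difference beyond the scatter.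

Compound 4 `C=C(Br)C(=O)Nc1cccc(-c2cn3nc(-c4cccc(OC)c4)sc3n2)c1` is not yet measured. It differs from compound 1 as follows: 3-methoxyphenyl in place of 3-methoxybenzyl on an aromatic carbon. Neither measured step bears on this change directly. The step of a 1.1-fold lower number from compound 2 to compound 3 (0.02 log units; within the scatter) only shows that the aryl group at the end of the benzyl chain may be varied without consequence, which says nothing about removing the chain carbon itself. The (1-bromoethenyl)carbonyl group, which the step of a 13-fold higher number from compound 1 to compound 3 (1.11 log units; beyond the scatter) marks as the main contributor in compound 1, is kept in compound 4. On that basis compound 4 is expected to give 5000 nM in this assay, with a range from 1500 nM to 20000 nM. Within the data shown here, the expected step is therefore a 1.6-fold higher number from compound 1 to compound 4 (0.21 log units; within the scatter), with a wide range in either direction, since no measured pair informs it.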

Compound 4, half-maximal inhibitory concentration: 1200 nM
Beside the measured number, compound 4's estimate is 4.2-fold (0.62 log units) above it, outside the stated range (below it).
By their numbers in this assay, from the lowest: compound 4; then compound 1; then compounds 3 and 2 (each within the scatter of the next).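

In this assay, within the data shown here, the step of a 2.6-fold lower number from compound 1 to compound 4 (0.41 log units; beyond the scatter) gives the first reading on the saturated chain carbon itself, and the 3-methoxyphenyl group sits directly on the aromatic carbon of the five-membered ring without any loss of inhibition. The earlier steps shown here changed only the aryl group at the end of the chain or the group on the aromatic nitrogen, so they left the link between this aryl group and the shared core untested; here, with the (1-bromoethenyl)carbonyl group kept, removing that link moves the number beyond the scatter, and the chain carbon proves unnecessary for inhibition in this pair. No data shown here explain this shift.

From the compounds shown here alone, it remains open whether the same shift appears when a free amine replaces the (1-bromoethenyl)carbonyl group, and whether 4-chlorophenyl on this aromatic carbon stays level with 3-methoxyphenyl as it does on the chain. Going by these compounds, the response to a longer chain, such as an ethylene link, or to a carboxylic acid on the aryl ring at this position is also open.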